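A few compounds are considered here, and "the series" means these few. Any claim that something is new, unique, unknown or untested is made for them only; others in the source may bear on it.

For the measured compounds named here, in a functional assay on K562 cells (Homo sapiens) for cytotoxicity, read by MTT assay, with a stated time of 48 h (a higher number here means a weaker inhibitor, a lower number a stronger inhibitor), compound 1 `Cc1ccc(CN2CCN(C(=O)CN[C@H]3CCN(S(=O)(=O)Cc4ccccc4)C3)CC2)cc1` gives 8200 nM and compound 2 `O=C(CN[C@H]1CCN(S(=O)(=O)Cc2ccccc2)C1)N1CCN(Cc2ccc(F)cc2)CC1` gives 14300 nM so compound 2 stands within the scatter of the only other measured value. Going by the values given here, the one measured step, fluoro in place of methyl on an aromatic carbon, is a 1.7-fold higher number from compound 1 to compound 2 (0.24 log units; within the scatter) and it is the only evidence on changes to this aromatic ring. Compound 3 `O=C(CN[C@H]1CCN(S(=O)(=O)Cc2ccccc2)C1)N1CCN(Cc2ccc(Cl)cc2Cl)CC1` differs from compound 2 as follows: 2,4-dichlorophenyl in place of 4-fluorophenyl on a saturated chain carbon bound to an amine nitrogen in a ring with 2,4-dichlorophenyl in place of 4-fluorophenyl on a saturated chain carbon bound to an amine nitrogen in a ring. Among the compounds with values here, no measured step covers this exact change, so in this assay no shift beyond the scatter is expected, and no direction is firmly favoured. The estimated step is a 1.3-fold lower number from compound 2 to compound 3 (0.11 log units; within the scatter) and it is expected to stay small. For compound 3 the estimate is 11000 nM with an expected range from 4500 nM to 25000 nM in this assay.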

Compound 3, half-maximal inhibitory concentration: 4300 nM
For compound 3 the middle estimate is 2.6-fold (0.41 log units) above the measured one; the whole stated range lies above it.
By their numbers in this assay, from the lowest: compounds 3, 1 and 2 (each within the scatter of the next, the first and the last beyond it).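

In this assay, for the compounds shown here, a 3.3-fold lower number from compound 2 to compound 3 (0.52 log units; beyond the scatter) is the first step at this position, on a saturated chain carbon bound to an amine nitrogen in a ring, to lie beyond the scatter; the earlier fluoro for methyl change did not. The same 2,4-dichlorophenyl group set against 4-methylphenyl gives a 1.9-fold lower number from compound 1 to compound 3 (0.28 log units; within the scatter) and stays within the scatter, so the change of aromatic group registers only against 4-fluorophenyl, and compound 1 is not separated from either of the others. Nothing available here accounts for the step from 4-fluorophenyl to 2,4-dichlorophenyl. On these data alone, whether a single chlorine on the phenyl ring would be enough to give this step remains open. So does how a methoxy group, a nitrile or a carboxylic acid on that ring would read in this assay against these three compounds.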